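A carbonyl substituent swap from compound 2 to compound 3

A few compounds are considered here, and "the series" means these few. Any claim that something is new, unique, unknown or untested is made for them only; others in the source may bear on it.

Measured in a functional assay on MCF7 cells (Homo sapiens) for cytotoxicity, read by colony formation; a higher number here means a weaker inhibitor, a lower number a stronger inhibitor:
- compound 1 `COC(=O)C1=CO[C@@H](O[C@@H]2O[C@H](COC(c3ccccc3)(c3ccccc3)c3ccccc3)[C@@H](OC(=O)O)[C@H](OC(C)=O)[C@H]2OC(C)=O)[C@@H]2[C@@H](C)[C@@H](OC(C)=O)C[C@H]12`: 1.2 ug/mL
- compound 2 `CCC(=O)OC[C@H]1O[C@@H](O[C@@H]2OC=C(C(=O)OC)[C@H]3C[C@H](OC(C)=O)[C@H](C)[C@@H]23)[C@H](OC(C)=O)[C@@H](OC(C)=O)[C@@H]1OC(C)=O`: 4.26 ug/mL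

Compound 2 holds the higher of the two numbers, making it the weaker inhibitor, and the gap to compound 1 lies beyond the scatter. In compound 3 `COC(=O)C1=CO[C@@H](O[C@@H]2O[C@H](COC(=O)C=C(C)C)[C@@H](OC(C)=O)[C@H](OC(C)=O)[C@H]2OC(C)=O)[C@@H]2[C@@H](C)[C@@H](OC(C)=O)C[C@H]12`, 2-methylprop-1-en-1-yl stands in place of ethyl on a carbonyl carbon (2-methylprop-1-en-1-yl in place of ethyl on a carbonyl carbon). Going by the values given here, no measured pair differs in one place, so the data give no direct guide to this change. In this assay, the estimated 1.4-fold lower number from compound 2 to compound 3 (0.15 log units; within the scatter) is expected to be small, slightly downward and within the scatter. For compound 3 the expected value is 3 ug/mL, with an estimated range of 1 ug/mL to 9 ug/mL.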

Compound 3, half-maximal inhibitory concentration: 4.65 ug/mL
The estimate for compound 3 lay 1.6-fold (0.19 log units) below the measured number; the measured number falls inside the stated range.
By their numbers in this assay, from the lowest: compound 1; then compounds 2 and 3 (each within the scatter of the next).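

In this assay, 2-methylprop-1-en-1-yl in place of ethyl on a carbonyl carbon gives a 1.1-fold higher number from compound 2 to compound 3 (0.04 log units; within the scatter) and so no change that can be read. This one-place step shows that this position accepts the larger group, with its double bond, without a shift beyond the scatter. No available evidence bears on this result.

These compounds leave open whether the double bond and the added carbons each have no effect or offset each other. They also leave open whether a saturated longer chain, an amine or a carboxylic acid on this carbonyl carbon would be accepted equally.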